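One Ring Exchange Tried on a Second Core

The source may report more compounds than this note shows. Statements on the series, on what has been measured and on what is new or still open speak of the compounds shown alone.

Four compounds are considered here, all tested in a functional assay on HT-29 cells (Homo sapiens) for inhibition, read by MTT assay, with a stated time of 48 h; a lower number here means a stronger inhibitor, a higher number a weaker inhibitor. Compound 1 `CN1CCN(c2ccc(Nc3ncc4c(n3)N(C3CCCC3)CC(=O)N4)cc2)CC1` gives 5220 nM in this assay. Compound 2 `O=C1CN(C2CCCC2)c2nc(Nc3ccc(N4CCCCC4)cc3)ncc2N1` gives 5540 nM in this assay. The two differ in one place, piperidin-1-yl in place of 4-methylpiperazin-1-yl on an aromatic carbon and this change produced a 1.1-fold higher number from compound 1 to compound 2 (0.03 log units; within the scatter).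

Compound 3 `CN1CCN(c2ccc(Nc3ncc4c(n3)N(C3CCCC3)CC(=O)N4C)nc2)CC1` gives 11100 nM in this assay. Its core differs from the core of compound 1, but that difference is not broken down here. Compound 4 `CN1C(=O)CN(C2CCCC2)c2nc(Nc3ccc(N4CCCCC4)cn3)ncc21` has not yet been measured in this assay. It differs from compound 3 in one place, piperidin-1-yl in place of 4-methylpiperazin-1-yl on an aromatic carbon and this is the same kind of change as that from compound 1 to compound 2, not the same one: in compound 1 the exchange sits on a six-membered aromatic ring of carbon only, whereas in compound 3 it sits on a six-membered aromatic ring with one nitrogen, two atoms from the ring nitrogen, para to a large group in both cases.

For compound 4 the expected step is a 1.1-fold higher number from compound 3 to compound 4 (0.03 log units; within the scatter) in this assay, because a 1.1-fold higher number from compound 1 to compound 2 (0.03 log units; within the scatter) shows that the same exchange on the earlier core left the number essentially unchanged. On that basis compound 4 is estimated at 12000 nM in this assay. The expected range for compound 4 runs from 6000 nM to 25000 nM.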

Compound 4, half-maximal inhibitory concentration: 12500 nM
Beside the measured number, compound 4's estimate is 1.0-fold (0.02 log units) below it; the range from low to high includes it.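

In this assay, exchanging 4-methylpiperazin-1-yl for piperidin-1-yl on the second core gave a 1.1-fold higher number from compound 3 to compound 4 (0.05 log units; within the scatter), so the number did not move beyond the scatter, and the earlier result carried over to this pair. Set side by side, the two steps agree: the same change on two cores in this assay, a 1.1-fold higher number (0.03 log units; within the scatter) from compound 1 to compound 2 and a 1.1-fold higher number (0.05 log units; within the scatter) from compound 3 to compound 4, 1.1-fold (0.03 log units) apart, within the scatter of two such steps

This shows that, in these two matched pairs, the exchange made no readable difference, whether it sat on a six-membered aromatic ring of carbon only or on one with one nitrogen. It does not show that the same would hold on any further core, and it gives no reason why the number stayed put, nor does it separate the contribution of the core from that of the ring carrying the group, as compound 1 and compound 3 differ in more than one place.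

The compounds shown leave open whether a different group in this place, such as morpholin-4-yl or a chain ending in a carboxylic acid, would also leave the number unchanged. They also leave open whether a primary amine there would give a step beyond the scatter on either core.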